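The source may hold more compounds than are shown below. What is called first, only, known or untested is meant among the compounds shown, and "the series" means these compounds.

Among the measured compounds shown here, in a functional assay on HCT-116 cells (Homo sapiens) for inhibition (on this read-out higher numbers stand for an effect only at larger amounts of compound and lower numbers for an effect already at smaller amounts), compound 1 (`COc1cc(N2CCNCC2)ccc1Nc1nc(NC2CCCCC2)c2nc[nH]c2n1`) gives 160 nM, while compound 2 (`COc1cc(N2CCN(C(=O)C3CCC(O)CC3)CC2)ccc1Nc1nc(NC2CCCCC2)c2nc[nH]c2n1`) gives 14 nM, the lower of the two numbers so far. For the measured compounds named here, only one measured step bears on what follows: an 11-fold lower number from compound 1 to compound 2 (1.06 log units; beyond the scatter). That large step, beyond the scatter, placed (4-hydroxycyclohexyl)carbonyl on an amine nitrogen in a ring, where compound 1 carries hydrogen.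

Compound 3 (`COc1cc(N2CCN(C(=O)N3CCN(C)CC3)CC2)ccc1Nc1nc(NC2CCCCC2)c2nc[nH]c2n1`) keeps the carbonyl and alters only the group attached to it: 4-methylpiperazin-1-yl in place of 4-hydroxycyclohexyl on a carbonyl carbon. In other words, 4-methylpiperazin-1-yl stands in place of 4-hydroxycyclohexyl on a carbonyl carbon. Going by the values given here, no measured pair makes this exchange, so the data do not isolate the contribution of either group. Among the compounds with values here, the one available step shows what adding the whole acyl unit did, and that unit's carbonyl remains in compound 3. A shift beyond the scatter is therefore not expected in either direction. The expected outcome is a 1.4-fold higher number from compound 2 to compound 3 (0.15 log units; within the scatter), a small rise that stays within the scatter. For compound 3, the estimated value in this assay is 20 nM, with an expected range from 7 nM to 60 nM.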

Compound 3, half-maximal effective concentration: 18 nM
Beside the measured number, compound 3's estimate is 1.1-fold (0.05 log units) above it; the range from low to high includes it.
By their numbers in this assay, from the lowest: compounds 2 and 3 (each within the scatter of the next); then compound 1.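

Exchanging 4-hydroxycyclohexyl for 4-methylpiperazin-1-yl on a carbonyl carbon in this assay leaves the two compounds within the scatter of each other (a 1.3-fold higher number from compound 2 to compound 3 (0.11 log units; within the scatter)), although the leaving group has one six-membered non-aromatic ring of carbon only and 1 hydrogen-bond donor, and the entering group has one six-membered non-aromatic ring with 2 hetero atoms and 0 hydrogen-bond donors. Against the hydrogen on the amine nitrogen in a ring, the new acyl group also gives a step beyond the scatter (an 8.9-fold lower number from compound 1 to compound 3 (0.95 log units; beyond the scatter)), so two different groups on the carbonyl now share that result, and among these compounds it does not depend on the hydroxy-bearing carbon ring. The data shown offer no measurement that explains either step.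

As far as these compounds go, what remains open is how much of the step from the hydrogen belongs to the carbonyl itself and how much to the ring attached to it, which a plain acetyl group on the same nitrogen or a methanesulfonyl group in place of the acyl unit would address. From the compounds shown here alone, it is also open whether a smaller amine such as dimethylamino on the carbonyl carbon would stay within the scatter of compound 2 and compound 3.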